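The compounds below may be only part of what the source reports. "The series", "measured", "known", "first", "only" and "open" are said of these compounds alone.

Measured so far in an ADME assay on 2209-23 cells (Homo sapiens) for cytotoxicity, read by WST assay and thymidine incorporation; on this read-out higher numbers stand for lower toxicity in this test and lower numbers for higher toxicity in this test:

- compound 1 `CC(C)CCN1C(=O)C(C2=CS(=O)(=O)c3cc(NS(C)(=O)=O)ccc3N2)=C(O)[C@@H]1C(C)(C)C`: > 50000 nM
- compound 2 `CC(C)(C)[C@H]1C(O)=C(C2=CS(=O)(=O)c3cc(NS(C)(=O)=O)cc(F)c3N2)C(=O)N1Cc1ccc(F)cc1`: > 50000 nM
- compound 3 `CC(C)(C)[C@H]1C(O)=C(C2=CS(=O)(=O)c3cc(C#N)ccc3N2)C(=O)N1Cc1ccc(F)cc1`: > 50000 nM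

Each of these three values is a limit of this assay, not a measured number, since all three sit at the limit of > 50000 nM in this assay, at which 3 of the 3 values shown sit. Compound 1 therefore stands at the same limit as the others, and nothing in the data separates it from compound 2 or compound 3.

Compound 4 `CC(C)(C)[C@H]1C(O)=C(C2=CS(=O)(=O)c3cc(NS(C)(=O)=O)ccc3N2)C(=O)N1Cc1ccccc1` differs from compound 1 by phenyl in place of isobutyl on a saturated chain carbon bound to an amide-type nitrogen in a ring. Among the compounds with values here, no measured pair shows what this change does, so the expectation rests only on the three limits. Compound 4 is expected to show a step that the limit leaves unreadable from compound 1 to compound 4, that is, none beyond the scatter. Compound 4 is estimated at 60000 nM, within 20000 nM to 200000 nM, most likely reported again as a limit.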

Compound 4, half-maximal cytotoxic concentration: > 50000 nM
Compound 4 ended at the assay's limit; the forecaster's own chance of this, stated with the estimate: 85%; the middle value is on the limit's open side.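

Compound 1 and compound 4 both stand at a limit of the assay, so no step can be read between them: the limit of > 50000 nM in this assay, at which 4 of the 4 values shown sit.

The compounds shown leave open at what concentration any of them would harm these cells, and whether swapping groups changes that concentration.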